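The compounds below may be only part of what the source reports. "The series", "measured", "known", "first", "only" and "open" are said of these compounds alone.

In a functional assay on J774.A1 cells (Mus musculus) for inhibition, read by Griess assay, with stated times of 1 h and 24 h (on this read-out higher numbers stand for weaker inhibition and lower numbers for stronger inhibition), three compounds with a shared core have been measured. Compound 1 `CCCOc1ccccc1C1CC(=O)c2ccccc2O1` gives 44600 nM, compound 2 `CCCCCOc1ccccc1C1CC(=O)c2ccccc2O1` gives 39300 nM, and compound 3 `CC(C)=CCOc1ccccc1C1CC(=O)c2ccccc2O1` gives 34300 nM. Compound 3 lies within the scatter of both others, so these numbers do not separate the three compounds.

The next compound is compound 4 `CCCCOc1ccccc1C1CC(=O)c2ccccc2O1`. It differs from compound 3 as follows: propyl in place of 2-methylprop-1-en-1-yl on a saturated chain carbon bound to an oxygen on an aromatic ring. The same difference can also be read as (3-methylbut-2-en-1-yl)oxy to butoxy.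

Within the data shown here, three measured steps bear on this change. Lengthening the saturated chain gave a 1.1-fold lower number from compound 1 to compound 2 (0.05 log units; within the scatter), and the chain of compound 4 is longer than that of compound 1 and shorter than that of compound 2. Exchanging a saturated chain for the unsaturated one gave a 1.3-fold lower number from compound 1 to compound 3 (0.11 log units; within the scatter) and a 1.1-fold lower number from compound 2 to compound 3 (0.06 log units; within the scatter). All three steps are small and within the scatter, so no step beyond the scatter is expected in this assay, and any direction is only tentative. The estimated step is a 1.1-fold higher number from compound 3 to compound 4 (0.06 log units; within the scatter), which is expected to remain within the scatter. Compound 4 is estimated at 39000 nM, with an expected range of 26000 nM to 58000 nM.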

Compound 4, half-maximal inhibitory concentration: 47700 nM
Compound 4: middle estimate off by 1.2-fold (0.09 log units), on the low side; the range from low to high includes it.
By their numbers in this assay, from the lowest: compounds 3, 2, 1 and 4 (each within the scatter of the next).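

Replacing the (3-methylbut-2-en-1-yl)oxy group with butoxy, which removes the double bond outside the aromatic rings, gives a 1.4-fold higher number from compound 3 to compound 4 (0.14 log units; within the scatter) in this assay, so these numbers do not separate the unsaturated chain from the saturated butyl chain at this place. The saturated chains also stay unresolved, with the added methyl giving a 1.1-fold higher number from compound 1 to compound 4 (0.03 log units; within the scatter) and hydrogen in place of methyl giving a 1.2-fold higher number from compound 2 to compound 4 (0.08 log units; within the scatter) on the same chain. With compound 4 filling the gap in chain length between compound 1 and compound 2, the three saturated chains show no trend with length in this assay, and all four chains on this oxygen now lie within the scatter of one another.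

No independent measurement is available to account for these small differences. On these data alone, all four groups are plain hydrocarbon chains, so it remains open whether an amine, a carboxylic acid or a much longer chain at this place would move the number beyond the scatter, and in which direction.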